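Oxolan-3-yl to pyrimidin-4-yl: notes on residence time

The source may hold more compounds than are shown below. What is called first, only, known or untested is meant among the compounds shown, and "the series" means these compounds.

Measured in an ADME assay on the whole organism (strain Sprague-Dawley) with Rattus norvegicus as the target, at a dose of 0.5 mg/kg by the intravenous route; a higher number here means that the compound lasts longer, a lower number that the compound disappears faster:
compound 1 `CC(C)(C)C#Cc1cc(N(C(=O)[C@H]2CC[C@H](C)CC2)[C@H]2CC[C@@H](Oc3cccnc3)CC2)c(C(=O)O)s1` gives 0.2 h
compound 2 `CC(C)(C)C#Cc1cc(N(C(=O)[C@H]2CC[C@H](C)CC2)[C@H]2CC[C@H](OC3CCOC3)CC2)c(C(=O)O)s1` gives 3.5 h
compound 3 `C[C@@H]1CC[C@@H](C(=O)N(c2cc(C#CC(C)(C)C)sc2C(=O)O)[C@H]2CC[C@H](OC3CCOC3)CC2)[C@@H](O)C1` gives 1.9 h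

Compound 2 stands at the upper end of this small set, level with compound 3 within the scatter and clearly above compound 1. The next structure, compound 4 `CC(C)(C)C#Cc1cc(N(C(=O)[C@H]2CC[C@H](C)CC2)[C@H]2CC[C@H](Oc3ccncn3)CC2)c(C(=O)O)s1`, departs from compound 2 in one place: pyrimidin-4-yl in place of oxolan-3-yl on an oxygen on a saturated carbon.

Among the measured compounds shown here, the only measured step, a 1.8-fold lower number from compound 2 to compound 3 (0.27 log units; within the scatter), concerns hydroxy in place of hydrogen on a saturated ring carbon. It lies at a different place and within the scatter, so it says little about this change. For the measured compounds named here, no measured step covers the exchange itself. The closest evidence is compound 1 (0.2 h), which also carries an aromatic ring on that oxygen but is not a clean match for compound 4, so only part of its gap to compound 2 is carried over. The expected change is a 5.8-fold lower number from compound 2 to compound 4 (0.77 log units; beyond the scatter), towards faster disappearance. Compound 4 is therefore estimated at 0.6 h (expected range 0.2 h to 2 h).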

Compound 4, mean residence time: 7.1 h
For compound 4 the middle estimate is 12-fold (1.07 log units) below the measured one; the whole stated range lies below it.
By their numbers in this assay, from the lowest: compound 1; then compounds 3 and 2 (each within the scatter of the next); then compound 4.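

In this assay the exchange of oxolan-3-yl for pyrimidin-4-yl on an oxygen on a saturated carbon gives a 2.0-fold higher number from compound 2 to compound 4 (0.31 log units; beyond the scatter) in a modest step, the only measured one at this place, so residence time is kept here and does not fall with the new ring. An aromatic ring on that oxygen therefore does not in itself go with fast disappearance, although compound 1 at 0.2 h stands against any general reading of this kind; it differs from compound 4 in more than one place, so its short residence time cannot be assigned to the ring on the oxygen alone. The data at hand offer no measurement that accounts for the step.

Going by these compounds, it remains open whether a phenyl ring or an open methoxyethyl chain on the same oxygen would keep residence time at this level, and whether an amine on the pyrimidin-4-yl ring would change it. Also open, on these data alone, is whether the hydroxy on a saturated ring carbon, seen in a 1.8-fold lower number from compound 2 to compound 3 (0.27 log units; within the scatter), would act the same way in the setting of compound 4.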